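The compounds below may be only part of what the source reports. "The series", "measured", "known", "first", "only" and "open" are said of these compounds alone.

Working notes on the series. Among the compounds with values here, in a functional assay on HCT-116 cells (Homo sapiens) for inhibition, read by MTT assay, with a stated time of 72 h (a lower number here means a stronger inhibitor of growth, a higher number a weaker inhibitor of growth), compound 3 `O[C@H](COCCOC[C@@H](O)Cc1cn(Cc2ccc(C(F)(F)F)cc2)nn1)Cc1ccc(-c2ccccc2)cc1` gives 2500 nM, the only number so far. For compound 1 `O[C@H](COCCOC[C@@H](O)Cc1cn(-c2cncnc2)nn1)Cc1ccc(-c2ccccc2)cc1` this assay reports only a limit, > 100000 nM. For compound 2 `O[C@H](COCCOC[C@@H](O)Cc1c[nH]nn1)Cc1ccc(-c2ccccc2)cc1` this assay likewise reports only a limit, > 100000 nM. The measured steps of an at least 40-fold lower number from compound 1 to compound 3 (1.60 log units; beyond the scatter) and an at least 40-fold lower number from compound 2 to compound 3 (1.60 log units; beyond the scatter) are both large, and the step that the two limits leave unreadable from compound 1 to compound 2 cannot be sized. Compound 4 `O[C@H](COCCOC[C@@H](O)Cc1cn(-c2ccc3c(c2)OCCO3)nn1)Cc1ccc(-c2ccccc2)cc1` differs from compound 3 by 2,3-dihydro-1,4-benzodioxin-6-yl in place of 4-(trifluoromethyl)benzyl on an aromatic nitrogen. This returns to an aromatic group set directly on an aromatic nitrogen, as in compound 1, which sits at the limit of > 100000 nM in this assay, at which 2 of the 3 values shown sit. The step of a 10-fold higher number from compound 3 to compound 4 (1.00 log units; beyond the scatter) is therefore expected to be an increase in this assay. Compound 4 is estimated at 25000 nM, with a range from 5000 nM to 100000 nM.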

Compound 4, concentration for 50% growth inhibition: 16500 nM
Compound 4: the middle estimate sits 1.5-fold (0.18 log units) above what was measured, and the stated range covers the measured number.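

Pyrimidin-5-yl and 2,3-dihydro-1,4-benzodioxin-6-yl are both aromatic groups set directly on the aromatic nitrogen, yet the change between them gives an at least 6.0-fold lower number from compound 1 to compound 4 (0.78 log units; beyond the scatter), so direct attachment of an aromatic group does not by itself leave a compound at the limit. Hydrogen on that nitrogen gives a similar reading, an at least 6.0-fold lower number from compound 2 to compound 4 (0.78 log units; beyond the scatter), while 4-(trifluoromethyl)benzyl keeps the advantage, a 6.6-fold higher number from compound 3 to compound 4 (0.82 log units; beyond the scatter). The values of compound 1 and compound 2 are limits, not numbers: the limit of > 100000 nM in this assay, at which 2 of the 4 values shown sit.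

Still open, on these data alone, is whether the benzyl link or the trifluoromethyl group carries the advantage of compound 3. Plain benzyl and 4-(trifluoromethyl)phenyl on this nitrogen would separate the two.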